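Fluoro for hydrogen on the core of compound 1

This account rests on a few compounds, and the source may have more. Where it says the series, first, only, none or still open, it means among the compounds named here.

Measured compounds:
Compound 1 `CCCCCn1c(N)nc2ccccc21` gives 3230 nM in an assay on HEK293 cells for agonist activity at Toll-like receptor 8 (Homo sapiens), read by reporter gene assay; a lower number here means that less compound is needed, a higher number that more compound is needed for the effect.
Compound 2 `CCCCCn1c(N)nc2cccc(C)c21` gives 6610 nM in this assay.

Compound 1 holds the lower of the two numbers. Among the compounds with values here, the one measured step, a 2.0-fold higher number from compound 1 to compound 2 (0.31 log units; beyond the scatter), shows a methyl in place of hydrogen on an aromatic carbon raising the number modestly. Compound 3 `CCCCCn1c(N)nc2c(F)cccc21` differs from compound 1 by fluoro in place of hydrogen on an aromatic carbon. This bears on the methyl step only loosely, since the entering group is fluorine and the place differs, so a small change in either direction or none beyond the scatter is expected. Compound 3 is therefore estimated at 4000 nM, between 1800 nM and 9000 nM, a step of a 1.2-fold higher number from compound 1 to compound 3 (0.09 log units; within the scatter).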

Compound 3, half-maximal effective concentration: "not active" (no number reported)
Nothing numeric was reported for compound 3; no gap can be computed for the estimate.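

Within the data shown here, compound 3 is reported as not active in this assay, without a number, so no step from compound 1 to compound 3 can be read. No measurement shown accounts for this result. The compounds shown leave open whether fluoro elsewhere on the core of compound 1 would give a measurable number.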